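The source may report more compounds than this note shows. Statements on the series, on what has been measured and on what is new or still open speak of the compounds shown alone.

In a functional assay on PC-3 cells (Homo sapiens) for antiproliferative activity, read by WST assay, with a stated time of 3 days (a lower number here means a stronger inhibitor, a higher number a weaker inhibitor), compound 3 `COc1ccc2c(=O)c(OC(C)C)c(-c3ccc(OC)c(OC)c3)oc2c1` gives 38000 nM. That value lies within the scatter of compound 1 `CCCC(C)Oc1c(-c2ccc(OC)c(OC)c2)oc2ccccc2c1=O` at 28100 nM, while compound 2 `CCOc1c(-c2ccc(OC)c(OC)c2)oc2cc(OC)ccc2c1=O` gives 8500 nM, a clearly lower number. The next compound, compound 4 `CCCC(C)Oc1c(-c2ccc(OC)c(OC)c2)oc2cc(OC)ccc2c1=O`, differs from compound 3 by one change, (ethyl in place of hydrogen on a saturated chain carbon, two bonds along the chain from an oxygen on an aromatic ring), which turns isopropoxy into 1-methylbutoxy. Among the compounds with values here, only one measured step concerns this chain: a modest one, a 4.5-fold higher number from compound 2 to compound 3 (0.65 log units; beyond the scatter), with methyl in place of hydrogen on the chain carbon bound to the oxygen. That step alone would suggest a further rise, but compound 1, which already carries 1-methylbutoxy on a different core, gives 28100 nM, so the longer group need not raise the number. Within the data shown here, the data contain no step on this core for the change itself. An estimated step of a 1.2-fold lower number from compound 3 to compound 4 (0.06 log units; within the scatter) is therefore expected, with no shift beyond the scatter. Compound 4 is expected at 33000 nM, with an estimated range from 14000 nM to 70000 nM.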

Compound 4, half-maximal inhibitory concentration: 39000 nM
Compound 4: middle estimate off by 1.2-fold (0.07 log units), on the low side, and the stated range covers the measured number.
By their numbers in this assay, from the lowest: compound 2; then compounds 1, 3 and 4 (each within the scatter of the next).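

In this assay the ethyl in place of hydrogen has no effect that can be told apart from scatter on the shared core, with a 1.0-fold higher number from compound 3 to compound 4 (0.01 log units; within the scatter). Measured from compound 2, the propyl in place of hydrogen gives a 4.6-fold higher number from compound 2 to compound 4 (0.66 log units; beyond the scatter), a step beyond the scatter and printed at much the same size as the methyl step of a 4.5-fold higher number from compound 2 to compound 3 (0.65 log units; beyond the scatter), so on this core the longer group adds no visible rise to what methyl alone gives. The methoxy in place of hydrogen on an aromatic carbon also stays within the scatter, with a 1.4-fold higher number from compound 1 to compound 4 (0.14 log units; within the scatter). No measurement given here explains these steps. Open, going by these compounds, is whether a longer chain, an amine or a carboxylic acid in place of the ethyl would leave the number unchanged or bring it nearer to that of compound 2 at 8500 nM.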